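The compounds below may be only part of what the source reports. "The series", "measured", "known", "first", "only" and "open" are said of these compounds alone.

Measured compounds in an assay on isolated protein for displacement of a labelled ligand from melanin-concentrating hormone receptor 1 (Homo sapiens); on this read-out higher numbers stand for weaker inhibition and lower numbers for stronger inhibition:

- compound 1 `O=C(CCc1ccc(C(F)(F)F)cc1)Nc1ccc2nc(N3CCC3)ccc2c1`: 4 nM
- compound 2 `O=C(CCc1ccc(C(F)(F)F)cc1)Nc1ccc2nc(N3CC4CC3CO4)ccc2c1`: 13 nM
- compound 3 `O=C(CCc1ccc(C(F)(F)F)cc1)Nc1ccc2nc(N3CCCCC3)ccc2c1`: 12 nM

Compound 3 stands second highest of the three numbers. Its nearest neighbour is compound 2, with a 1.1-fold lower number from compound 2 to compound 3 (0.03 log units; within the scatter), so the two cannot be told apart. Its furthest is compound 1, with a 3.0-fold higher number from compound 1 to compound 3 (0.48 log units; beyond the scatter).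

Compound 4 `CCN(CC)c1ccc2cc(NC(=O)CCc3ccc(C(F)(F)F)cc3)ccc2n1` carries the change (diethylamino in place of piperidin-1-yl on an aromatic carbon), on the carbon next to the ring nitrogen, meta to a fused ring and para to a fused ring.

Going by the values given here, two measured steps touch the same position. From compound 1 the amine ring was enlarged, giving a 3.0-fold higher number from compound 1 to compound 3 (0.48 log units; beyond the scatter); replacing it with a bridged bicyclic gave a 3.3-fold higher number from compound 1 to compound 2 (0.51 log units; beyond the scatter). Both departures from the four-membered ring cost a modest amount, and the two larger groups sit together within the scatter. Among the compounds with values here, no measured step removes the ring altogether, so the open-chain diethylamino has no direct precedent here. Given that the two larger cyclic groups behave alike, a group of similar size without a ring is expected to stay close to compound 3, with the step of a 1.2-fold lower number from compound 3 to compound 4 (0.08 log units; within the scatter) expected to lie within or only just beyond the scatter.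

For compound 4 in this assay the expected value is 10 nM, with a range from 4 nM to 30 nM.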

Compound 4, half-maximal inhibitory concentration: 88 nM
Estimate against measurement, compound 4: 8.8-fold (0.94 log units) below, and the stated range ends below it.
By their numbers in this assay, from the lowest: compound 1; then compounds 3 and 2 (each within the scatter of the next); then compound 4.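

In this assay, keeping a ring at the carbon next to the ring nitrogen matters in a way the cyclic groups alone could not show: diethylamino in place of piperidin-1-yl gives a 7.3-fold higher number from compound 3 to compound 4 (0.87 log units; beyond the scatter), and the same open chain in place of the bridged bicyclic group gives a 6.8-fold higher number from compound 2 to compound 4 (0.83 log units; beyond the scatter). Against azetidin-1-yl the change gives a 22-fold higher number from compound 1 to compound 4 (1.34 log units; beyond the scatter), the largest step yet seen at this position and the only one of these steps printed as large. Heavy-atom count therefore does not order these four groups, since diethylamino falls between azetidin-1-yl and piperidin-1-yl on that count yet gives the highest number, while all three ring-bearing groups stand lower.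

No supporting measurement bears on why the open chain stands apart from the rings. The compounds shown leave open whether dimethylamino or pyrrolidin-1-yl on this carbon would stay with the cyclic amines or move towards compound 4, and so whether the shift follows the loss of the ring or the length of the two ethyl chains.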